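The source may hold more compounds than are shown below. What is called first, only, known or untested is meant among the compounds shown, and "the series" means these compounds.

In a functional assay (aorta) for inhibition, with Oryctolagus cuniculus as the target (a higher number here means a weaker inhibitor, a lower number a stronger inhibitor), compound 1 `CCO/C(O)=C1\C(C)=NC(=S)N(C(=O)OC2CCN(Cc3ccccc3)CC2)C1c1ccccc1C(F)(F)F` gives 9 nM and stands as the stronger of the two inhibitors measured so far. Compound 2 `CC1=C(C(=O)OC(C)C)C(c2cccc([N+](=O)[O-])c2)N(C(=O)O[C@@H](C)CN(C)Cc2ccccc2)C(=O)N1` gives 57 nM in this assay and so holds the higher of the two numbers, a gap that lies beyond the usual scatter. The two differ in several places, so their values show no effect of any single change.

Compound 3 `CC1=C(C(=O)OC(C)C)C(c2cccc([N+](=O)[O-])c2)N(C(=O)O[C@H](C)CN(C)Cc2ccccc2)C(=O)N1` is the partner of compound 2, and the difference is this: the two compounds have the same atoms and bonds; at least one stereo element is drawn with a configuration in one of them and without one in the other: 1 of 2 stereo elements differ; a stereocentre at a saturated chain carbon is drawn S in compound 2 and R in compound 3 and nothing else. The two compounds have the same atoms and bonds, and a stereocentre at a saturated chain carbon is drawn S in compound 2 and R in compound 3. Among the measured compounds shown here, no pair differing only in this way has been measured yet, so the data give no direct guide to the size or direction of such a step. In this assay no step beyond the scatter is expected, with neither direction favoured, and the anchor is compound 2 at 57 nM in that assay. The estimate means an expected 1.1-fold lower number from compound 2 to compound 3 (0.06 log units; within the scatter) within the scatter. Compound 3 is estimated at 50 nM with an expected range from 17 nM to 150 nM in this assay once measured.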

Compound 3, half-maximal inhibitory concentration: 64 nM
Compound 3: the middle estimate sits 1.3-fold (0.11 log units) below what was measured; the range from low to high includes it.
By their numbers in this assay, from the lowest: compound 1; then compounds 2 and 3 (each within the scatter of the next).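

In this assay, among the compounds shown here, turning the stereocentre at the saturated chain carbon from S to R gives a 1.1-fold higher number from compound 2 to compound 3 (0.05 log units; within the scatter), the first step that can be read for a single change. Within this one pair, then, the drawn configuration at this chain carbon shifts the number by no more than the scatter and shows no preference for either form, something the comparison of compound 1 with compound 2, which differ in several places, could not address. The reading carries one qualification, which lies in how the structures are drawn: the fact that one of compounds 2 and 3 is drawn with a defined configuration and the other without, at the place where they differ

What the compounds shown leave open is whether the two configurations would still read alike with an ethyl group in place of the methyl at this stereocentre, or with a primary amine in place of the tertiary amine carrying the methyl and benzyl groups. They also do not tell whether the second stereo element, which does not change between compound 2 and compound 3, has any bearing on the number in this assay.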